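Amine tail exchange on the shared core: cytotoxicity notes

The source may report more compounds than this note shows. Statements on the series, on what has been measured and on what is new or still open speak of the compounds shown alone.

Three members of the series carry a measurement in a functional assay on A549 cells (Homo sapiens) for cytotoxicity, read by MTT assay, with a stated time of 72 h; on this read-out higher numbers stand for weaker inhibition and lower numbers for stronger inhibition. Compound 1 `CN1CCN(CCCCCn2c3c(c4ccccc42)C(=O)c2c[n+]([O-])c4ccccc4c2C3=O)CC1` gives 870 nM, the highest of the three numbers. Compound 2 `CC1(C)O[C@@H](CO)[C@H](Cn2cc(Cn3c4c(c5ccccc53)C(=O)c3c[n+]([O-])c5ccccc5c3C4=O)nn2)O1` gives 370 nM, and compound 3 `CC1(C)OCC(Cn2cc(Cn3c4c(c5ccccc53)C(=O)c3c[n+]([O-])c5ccccc5c3C4=O)nn2)O1` gives 80 nM. For the measured compounds named here, the only single-point step among the measured pairs, a 4.6-fold lower number from compound 2 to compound 3 (0.67 log units; beyond the scatter), concerns the dioxolane portion of the chain and says nothing about the amine tail. The gap from compound 1 to compound 2 and to compound 3 lies beyond the scatter, but those pairs differ at several places at once.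

Compound 4 `O=C1c2c[n+]([O-])c3ccccc3c2C(=O)c2c1c1ccccc1n2CCCCN1CCCCC1` differs from compound 1 in the tail only: piperidin-1-yl in place of (4-methylpiperazin-1-yl)methyl on a saturated chain carbon, four bonds along the chain from an aromatic nitrogen. The same exchange, cut one bond further out, reads 4-(4-methylpiperazin-1-yl)butyl to 3-(piperidin-1-yl)propyl. Going by the values given here, no measured step covers this kind of change, so no direction is supported, and the expectation is a step within the scatter. Compound 4 is therefore estimated at 650 nM in this assay, range 200 nM to 2000 nM, a step of a 1.3-fold lower number from compound 1 to compound 4 (0.13 log units; within the scatter) expected from compound 1.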

Compound 4, half-maximal inhibitory concentration: 150 nM
Estimate against measurement, compound 4: 4.3-fold (0.64 log units) above; the whole stated range lies above it.
By their numbers in this assay, from the lowest: compounds 3 and 4 (each within the scatter of the next); then compound 2; then compound 1.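

The tail is not a silent position: in this assay, piperidin-1-yl in place of (4-methylpiperazin-1-yl)methyl on a saturated chain carbon, four bonds along the chain from an aromatic nitrogen, gives a 5.8-fold lower number from compound 1 to compound 4 (0.76 log units; beyond the scatter). For the compounds shown here, this is the first measured step at the amine end of the chain, whereas the earlier step concerned only the dioxolane portion. The exchange alters ring and chain together, as the reading 4-(4-methylpiperazin-1-yl)butyl to 3-(piperidin-1-yl)propyl shows, so the step cannot be divided between them, and nothing available here gives a cause for it.

Still open, from the compounds shown here alone, is how 4-methylpiperazin-1-yl behaves on the shorter chain of compound 4, and piperidin-1-yl on the longer chain of compound 1. Also open, going by these compounds, is whether another amine tail, such as morpholin-4-yl or dimethylamino, would give a number like that of compound 4.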